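Swapping a Cyclohexyl for 2-Chlorophenyl on an Agonist

This account rests on a few compounds, and the source may have more. Where it says the series, first, only, none or still open, it means among the compounds named here.

Measured so far:
compound 1, `O=C(O)c1ccccc1-c1ccc(CCc2ncc(CC3CCCCC3)[nH]2)cc1`: 7.3 nM
compound 2, `CCCCc1cnc(C(Cc2ccc(-c3ccccc3C(=O)O)cc2)C(C)C)[nH]1`: 2240 nM

Of the compounds shown here, two have been tested in an in vitro functional assay on cells for agonist activity at Bombesin receptor subtype-3 (Mus musculus), read by luminescence and calcium flux; on this read-out lower numbers stand for an effect already at smaller amounts and higher numbers for an effect only at larger amounts of compound. Compound 1 gives 7.3 nM in this assay, the lowest of the two numbers. For the measured compounds named here, compound 2 gives 2240 nM in this assay, a far higher number that lies well beyond the scatter; no single-point step links these two compounds, so only their two values can be compared.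

Compound 3, `O=C(O)c1ccccc1-c1ccc(CCc2ncc(Cc3ccccc3Cl)[nH]2)cc1`, is not yet measured. It differs from compound 1 in one place:

2-chlorophenyl in place of cyclohexyl on a saturated chain carbon bound to an aromatic carbon

Going by the values given here, no pair of measured compounds shows this kind of change, so the expectation rests on compound 1 alone. Since compound 1 gives 7.3 nM and the change keeps the shared core intact, a modest step toward a higher number is expected in this assay, a 2.7-fold higher number from compound 1 to compound 3 (0.44 log units; beyond the scatter), of a size that could still fall within the scatter. Compound 3 is therefore estimated to give 20 nM in this assay, with a range from 4 nM to 100 nM.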

Compound 3, half-maximal effective concentration: 22 nM
Estimate against measurement, compound 3: 1.1-fold (0.04 log units) below, within the range that was stated.
By their numbers in this assay, from the lowest: compound 1; then compound 3; then compound 2.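

The saturated ring on a saturated chain carbon bound to an aromatic carbon can give way to an aromatic ring carrying chlorine at only a modest cost in this assay (a 3.0-fold higher number from compound 1 to compound 3 (0.48 log units; beyond the scatter)), so this position is not tied to cyclohexyl, and compound 3 keeps its effect at far smaller amounts than the higher numbers this series can reach. The change alters two things at once, since 2-chlorophenyl differs from cyclohexyl both in having an aromatic ring and in carrying a chlorine, and this single step cannot divide the shift between them. Nothing measured here explains the size of the shift.

A plain phenyl in the same place, giving benzyl in place of 2-chlorobenzyl, would separate the effect of the aromatic ring from that of the chlorine. Whether this position also takes a ring holding nitrogen, such as piperidinyl, or an open chain such as butyl in place of the ring, remains open from the compounds shown.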